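A few compounds are considered here, and "the series" means these few. Any claim that something is new, unique, unknown or untested is made for them only; others in the source may bear on it.

Compound 1 `CC[Si](C#Cc1ccc2c(c1)C=C([N+](=O)[O-])C(C(F)(F)F)O2)(CC)CC` was tested in a functional assay on 1321N1 cells for antagonist activity at P2Y purinoceptor 6 (Homo sapiens), read by fluorescence and calcium flux (a higher number here means a weaker inhibitor, a lower number a stronger inhibitor), where compound 1 gives 604 nM, the lower of the two numbers seen so far. Compound 2 `COC(=O)[C@H](C)NC(=O)c1ccc(C#Cc2ccc3c(c2)C=C([N+](=O)[O-])C(C(F)(F)F)O3)cc1`, in this assay, gives 6840 nM, a higher number that lies beyond the usual scatter. Compound 3 `CC(=O)NCC#Cc1ccc2c(c1)C=C([N+](=O)[O-])C(C(F)(F)F)O2` is not yet measured. Relative to compound 1 it shows this change: a group of 5 heavy atoms (3 carbon, 1 nitrogen, 1 oxygen; no ring) in place of a group of 7 heavy atoms (6 carbon, 1 silicon; no ring), on a triple-bonded carbon. A rise in the number is expected, of the size a 3.3-fold higher number from compound 1 to compound 3 (0.52 log units; beyond the scatter), since compound 2, which also carries an amide on the triple bond side, gives 6840 nM. For compound 3 the estimate is 2000 nM, with a range from 600 nM to 7000 nM.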

Compound 3, half-maximal inhibitory concentration: 7670 nM
The estimate for compound 3 lay 3.8-fold (0.58 log units) below the measured number; measured number outside the range, above it.
By their numbers in this assay, from the lowest: compound 1; then compounds 2 and 3 (each within the scatter of the next).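

On this triple-bonded carbon, putting acetamidomethyl in place of the silicon-bearing group changes the result in this assay by a 13-fold higher number from compound 1 to compound 3 (1.10 log units; beyond the scatter), a large step. The rest of the structure stays the same. Among the compounds shown here, this is the first rise that can be tied to this one place, and it shows that this group is far less well tolerated here. Nothing measured here accounts for the rise.

Still open, going by these compounds, is whether a tert-butyl group, with carbon in place of silicon, would stay close to compound 1. An amine or a carboxylic acid at this place is also untested in the compounds shown.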